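Compound 3 to compound 4: a series at its limit

A few compounds are considered here, and "the series" means these few. Any claim that something is new, unique, unknown or untested is made for them only; others in the source may bear on it.

In an ADME assay on H9c2 cells (Rattus norvegicus) for cytotoxicity, read by resazurin assay, with a stated time of 72 h (on this read-out lower numbers stand for higher toxicity in this test and higher numbers for lower toxicity in this test), all measured values are limits:
compound 1 `C/C(=N\Nc1nc(-c2ccc(F)cc2)cs1)c1ccc(Cl)c(Cl)c1` gives > 50000 nM as a limit
compound 2 `C/C(=N\Nc1nc(-c2ccc(Cl)cc2Cl)cs1)c1ccc(Cl)c(Cl)c1` gives > 50000 nM as a limit
compound 3 `C/C(=N\Nc1nc(-c2ccc(Br)cc2)cs1)c1ccc(Cl)c(Cl)c1` gives > 50000 nM as a limit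

Compound 3 gives only a limit, > 50000 nM and no number. The whole measured set shares this position, as the limit of > 50000 nM in this assay, at which 3 of the 3 values shown sit, shows.

Compound 4 `COc1ccc(-c2csc(N/N=C(\C)c3ccc(Cl)c(Cl)c3)n2)cc1` departs from compound 3 by methoxy in place of bromo on an aromatic carbon with methoxy in place of bromo on an aromatic carbon. Closest to this change is a step that the two limits leave unreadable from compound 1 to compound 3 and it too exchanges one group on an aromatic carbon. The other two are a step that the two limits leave unreadable from compound 1 to compound 2 and a step that the two limits leave unreadable from compound 2 to compound 3 and neither gives a size. No measured size or direction can therefore be carried over to this assay for this change.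

For compound 4 no step beyond the scatter is expected from compound 3, whose > 50000 nM is again only a limit. The expected result is a number no higher from compound 3 to compound 4 (the limit leaves the size open) with no direction favoured. The estimate for compound 4 is 50000 nM with an expected range from 20000 nM to 100000 nM and a further limit is the likeliest report.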

Compound 4, half-maximal cytotoxic concentration: > 50000 nM
Compound 4: only a limit was reported; the forecaster's own chance of this, stated with the estimate: 80%; the middle value lies on the limit itself.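

Compound 4 gives > 50000 nM in this assay, again a limit and not a number. No step from compound 1, compound 2 or compound 3 to compound 4 can be read: the limit of > 50000 nM in this assay, at which 4 of the 4 values shown sit.

The compounds shown leave open what number lies behind each limit and whether any exchange on this aromatic ring changes the read-out at all.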